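From sulfonyl to carbamoyl: compound 3 to compound 4

The source may report more compounds than this note shows. Statements on the series, on what has been measured and on what is new or still open speak of the compounds shown alone.

Measured in a functional assay on MDA-MB-231 cells (Homo sapiens) for antiproliferative activity, read by MTT assay, with a stated time of 24 h; a higher number here means a weaker inhibitor, a lower number a stronger inhibitor:
- compound 1 `O=C([C@H]1Cc2ccccc2N1)N1CCN(c2nccc(Oc3cc(Cl)cc(Cl)c3)n2)CC1`: > 50000 nM
- compound 2 `O=S(=O)(c1ccccc1)N1CCN(c2nccc(Oc3cc(Cl)cc(Cl)c3)n2)CC1`: > 50000 nM
- compound 3 `O=S(=O)(c1ccc(F)cc1)N1CCN(c2nccc(Oc3cc(Cl)cc(Cl)c3)n2)CC1`: > 50000 nM

Each of these three entries is a limit of the assay and not a number. Compound 3 therefore offers only its limit as a starting point, and it shares that standing with the other two compounds: the limit of > 50000 nM in this assay, at which 3 of the 3 values shown sit.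

Compound 4 `Cc1ccc(NC(=O)N2CCN(c3nccc(Oc4cc(Cl)cc(Cl)c4)n3)CC2)cc1` carries (4-methylphenyl)carbamoyl in place of (4-fluorophenyl)sulfonyl on an amine nitrogen in a ring.

Among the compounds with values here, the one measured step that bears on this change is a step that the two limits leave unreadable from compound 2 to compound 3, with fluoro in place of hydrogen on an aromatic carbon. It has no readable size, so it gives no measure for the exchange of the whole group. Compound 1, with a different group in the same place, also gives only a limit, > 50000 nM.

On this evidence, no step beyond the scatter is expected in this assay, and the assay will most likely report a limit again, although a measurable value cannot be excluded. The expected change is an at least 1.1-fold lower number from compound 3 to compound 4 (0.04 log units; that floor lies within the scatter). Compound 4 is estimated at 45000 nM, with an expected range of 10000 nM to 70000 nM.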

Compound 4, half-maximal inhibitory concentration: 11600 nM
The estimate for compound 4 lay 3.9-fold (0.59 log units) above the measured number, within the range that was stated.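

In this assay, the amine nitrogen in a ring proves to be a position that can move the read-out: (4-methylphenyl)carbamoyl in place of (4-fluorophenyl)sulfonyl gives an at least 4.3-fold lower number from compound 3 to compound 4 (0.63 log units; beyond the scatter), and the same group in place of phenylsulfonyl gives an at least 4.3-fold lower number from compound 2 to compound 4 (0.63 log units; beyond the scatter). A carbonyl on that nitrogen is not enough by itself, since compound 1 also has one and stays at a limit, whereas (4-methylphenyl)amino in place of 2,3-dihydro-1H-indol-2-yl on a carbonyl carbon gives an at least 4.3-fold lower number from compound 1 to compound 4 (0.63 log units; beyond the scatter). Compound 4 is the only compound shown with a number rather than a limit, so all three steps are floors and not full sizes, and the other compounds remain at the limit: the limit of > 50000 nM in this assay, at which 3 of the 4 values shown sit.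

The compounds shown do not separate the contribution of the carbamoyl link from that of the 4-methylphenyl ring, as no compound changes only one of these two parts. As far as these compounds go, it also remains open how the read-out would respond to an amine, a carboxylic acid or a longer alkyl chain in place of the methyl group on that ring.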